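This account rests on a few compounds, and the source may have more. Where it says the series, first, only, none or still open, it means among the compounds named here.

Values in a functional assay on MCF7 cells (Homo sapiens) for antiproliferative activity, read by MTT assay, with a stated time of 48 h; on this read-out lower numbers stand for stronger inhibition and higher numbers for weaker inhibition:
- compound 1 `Cc1ccc(C(=O)/C=C/c2cc(Br)cc(Br)c2Oc2c([N+](=O)[O-])cc(C(F)(F)F)cc2[N+](=O)[O-])cc1`: 1.44 ug/mL
- compound 2 `Cc1ccc(C(=O)/C=C/c2cccc(Br)c2Oc2c([N+](=O)[O-])cc(C(F)(F)F)cc2[N+](=O)[O-])cc1`: 0.55 ug/mL
- compound 3 `Cc1ccc(C(=O)/C=C/c2cccc(Cl)c2Oc2c([N+](=O)[O-])cc(C(F)(F)F)cc2[N+](=O)[O-])cc1`: 0.03 ug/mL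

Compound 1 has the highest number of the three and is the weakest inhibitor among them. Compound 4 `O=C(/C=C/c1cc(Br)cc(Br)c1Oc1c([N+](=O)[O-])cc(C(F)(F)F)cc1[N+](=O)[O-])c1ccc(F)cc1` keeps the core of compound 1 but has fluoro in place of methyl on an aromatic carbon, para to a large group: fluoro in place of methyl on an aromatic carbon. Among the compounds with values here, no measured step touches the 4-methylphenyl group. Two halogen steps bear on it only indirectly: a 2.6-fold lower number from compound 1 to compound 2 (0.42 log units; beyond the scatter) and an 18-fold lower number from compound 2 to compound 3 (1.26 log units; beyond the scatter). They show that single-atom changes can matter in this series, but they give no direction here, so no step beyond the scatter is expected in this assay. The expected change is a 1.2-fold lower number from compound 1 to compound 4 (0.08 log units; within the scatter). Compound 4 is estimated at 1.2 ug/mL, within an expected range of 0.3 ug/mL to 4.5 ug/mL.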

Compound 4, half-maximal inhibitory concentration: 8.06 ug/mL
Compound 4: the middle estimate sits 6.7-fold (0.83 log units) below what was measured; measured number above the stated range.
By their numbers in this assay, from the lowest: compound 3; then compound 2; then compound 1; then compound 4.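

Fluoro in place of methyl on an aromatic carbon, para to a large group, gives a 5.6-fold higher number from compound 1 to compound 4 (0.75 log units; beyond the scatter) in this assay. Within the data shown here, the 4-methylphenyl group, which no earlier step touched, is therefore not a silent place on the core of compound 1, and the change moves inhibition in the weaker direction. Nothing at hand accounts for this loss.
Going by these compounds, whether the same change would act alike on compound 2 or compound 3 stays open. So does how a methoxy group or an amine in place of methyl would read.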